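Cytotoxicity of three oxalamide analogues and a chloro-fluoro variant

This account rests on a few compounds, and the source may have more. Where it says the series, first, only, none or still open, it means among the compounds named here.

Measured compounds:
compound 1, `Cc1nc(C(NC(=O)C(=O)Nc2ccc(F)c(F)c2)C2CCCCN2)sc1CO`, > 87000 nM (a limit of the assay)
compound 2, `Cc1nc(C(NC(=O)C(=O)Nc2ccc(F)cc2F)C2CCCCN2)sc1CO`, > 110000 nM (a limit of the assay)
compound 3, `Cc1nc(C(NC(=O)C(=O)Nc2ccc(F)cc2F)C2CCCCN2)sc1CCO`, > 105000 nM (a limit of the assay)

In an ADME assay on MT2 cells (Homo sapiens) for cytotoxicity, read by XTT assay, with a stated time of 4 days (a lower number here means that less compound is tolerated, a higher number that more compound is tolerated), compound 1 reaches only the limit given above, with no number below it. The same holds for compound 2, whose value is a limit of this assay. Compound 3 likewise gives a limit and no number. Because each value is a limit, the step that the two limits leave unreadable from compound 1 to compound 2 cannot be read, and neither can a step that the two limits leave unreadable from compound 2 to compound 3. Compound 3 therefore stands at a limit among three limits, as the limit of > 105000 nM in this assay, at which 1 of the 3 values shown sits, the limit of > 110000 nM in this assay, at which 1 of the 3 values shown sits, and the limit of > 87000 nM in this assay, at which 1 of the 3 values shown sits, record.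

Compound 4, `Cc1nc(C(NC(=O)C(=O)Nc2ccc(F)c(Cl)c2)C2CCCCN2)sc1CCO`, has not yet been measured in this assay. It differs from compound 3 as follows: 3-chloro-4-fluorophenyl in place of 2,4-difluorophenyl on an amide-type nitrogen. The two measured steps bear on this change only in that both ring swaps and the chain extension left every compound at a limit. Among the measured compounds shown here, no step of readable size has been seen, so no step beyond the scatter is expected in this assay, and compound 4 is expected to sit at a limit as well. The expected step is an at least 1.0-fold lower number from compound 3 to compound 4 (0.02 log units; that floor lies within the scatter). For compound 4 the estimate in this assay is 100000 nM, with a range from 50000 nM to 200000 nM.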

Compound 4, half-maximal cytotoxic concentration: 94700 nM
For compound 4 the middle estimate is 1.1-fold (0.02 log units) above the measured one; the measured number falls inside the stated range.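

In this assay compound 4 gives 94700 nM, the only actual number among the four compounds shown, so this position on the amide-type nitrogen now has one measured read-out rather than limits alone. Among the compounds shown here, putting 3-chloro-4-fluorophenyl in place of 2,4-difluorophenyl gives an at least 1.1-fold lower number from compound 3 to compound 4 (0.04 log units; that floor lies within the scatter), the only step in the set with a readable size, though that size is only a floor and does not establish a real difference between the two compounds. The other steps shown, among compound 1, compound 2 and compound 3, cannot be read, and the floor itself rests on a limit, with compound 3 recorded only as one: the limit of > 105000 nM in this assay, at which 1 of the 4 values shown sits.

As far as these compounds go, how far the true step extends past that floor stays open, and so does whether the chlorine-bearing ring would give a measurable number on the shared core with a different side chain. Also open, from the compounds shown here alone, is what a plain phenyl or a 3,4-dichlorophenyl on the same amide-type nitrogen would give in this assay.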